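The source may hold more compounds than are shown below. What is called first, only, known or untested is meant among the compounds shown, and "the series" means these compounds.

Measured compounds:
- compound 1, `Cc1ccc(Oc2ccc(/C=N/Nc3nc4ccccc4s3)cc2)cc1`: 5.4
- compound 2, `O=C(CSc1nc2ccccc2s1)N/N=C/c1ccc(Oc2ccc(Br)cc2)cc1`: 5.7
- compound 3, `O=C(CSc1nc2ccccc2s1)N/N=C/c1ccc(Oc2ccc([N+](=O)[O-])cc2)cc1`: 5.3

In a physicochemical assay for lipophilicity, in phosphate buffer, measured as octanol-water partition, with a stated time of 24 h (a higher number here means a more lipophilic compound, a lower number a more polar compound), compound 1 sits between the other two, and its gaps to compound 3 and to compound 2 are both within the scatter, so none of the three can be called more or less lipophilic than the others. Compound 4, `O=[N+]([O-])c1ccc(Oc2ccc(/C=N/Nc3nc4ccccc4s3)cc2)cc1`, is not yet measured; it differs from compound 1 in one place: nitro in place of methyl on an aromatic carbon. Among the compounds with values here, the only measured step that introduces a nitro group on an aromatic carbon is a number 0.40 log units lower from compound 2 to compound 3 (beyond the scatter), although there bromo leaves rather than methyl. A downward step of similar size is therefore expected, a number 0.50 log units lower from compound 1 to compound 4 (beyond the scatter). Compound 4 is estimated at 4.9, between 4.5 and 5.3.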

Compound 4, partition coefficient: 5.1
Compound 4: the middle estimate sits 0.20 log units below what was measured, and the stated range covers the measured number.
By their numbers in this assay, from the lowest: compounds 4, 3, 1 and 2 (each within the scatter of the next, the first and the last beyond it).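

In this assay the change from methyl to nitro on this ring, para to a large group, gives a number 0.30 log units lower from compound 1 to compound 4 (within the scatter) and so cannot be told apart from repeat-measurement noise. The only other nitro step shown, where bromo leaves, is a number 0.40 log units lower from compound 2 to compound 3 (beyond the scatter) and does clear the scatter, so a nitro group entering does not give a readable step from every starting group.

From the compounds shown here alone, whether an amine, a carboxylic acid or a longer chain at this place would shift the number further stays open. Nothing available explains why the two nitro steps read differently.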